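Replacing a Bromo Group with Phenyl in Compound 2

The source may report more compounds than this note shows. Statements on the series, on what has been measured and on what is new or still open speak of the compounds shown alone.

Three compounds share one core and differ only in the aromatic group on an amide-type nitrogen, and all were tested in a functional assay on HCT-116 cells (Homo sapiens) for inhibition, read by colorimetric assay, with a stated time of 3 days; on this read-out higher numbers stand for weaker inhibition and lower numbers for stronger inhibition. Compound 1 `O=C(CCCCCCNC(=O)C(O)(O)C(F)(F)F)Nc1ccccc1Br`, carrying 2-bromophenyl, gives 14500 nM. Compound 3 `O=C(CCCCCCNC(=O)C(O)(O)C(F)(F)F)Nc1c(F)cc(F)cc1F`, carrying 2,4,6-trifluorophenyl, gives 22200 nM. Compound 2 `O=C(CCCCCCNC(=O)C(O)(O)C(F)(F)F)Nc1ccc(Br)cc1`, carrying 4-bromophenyl, gives 3130 nM, the lowest number of the three and so the strongest inhibition.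

Compound 4 `O=C(CCCCCCNC(=O)C(O)(O)C(F)(F)F)Nc1ccc(-c2ccccc2)cc1` has not yet been measured. It keeps all of compound 2 except for one change: phenyl in place of bromo on an aromatic carbon.

Two measured steps show how far changes to this aromatic group have moved the number. One is a 4.6-fold lower number from compound 1 to compound 2 (0.67 log units; beyond the scatter), and the other is a 7.1-fold higher number from compound 2 to compound 3 (0.85 log units; beyond the scatter). Both are modest, but neither adds a second ring, so they give only a rough size and no firm direction. A step no larger than these is therefore expected, with a slight lowering as a cautious guess. The expected change is a 1.3-fold lower number from compound 2 to compound 4 (0.10 log units; within the scatter). For compound 4 the estimated value is 2500 nM, with an expected range from 700 nM to 9000 nM.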

Compound 4, half-maximal inhibitory concentration: 4730 nM
Beside the measured number, compound 4's estimate is 1.9-fold (0.28 log units) below it, within the range that was stated.
By their numbers in this assay, from the lowest: compounds 2 and 4 (each within the scatter of the next); then compounds 1 and 3 (each within the scatter of the next).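

In this assay, a 1.5-fold higher number from compound 2 to compound 4 (0.18 log units; within the scatter), so exchanging bromo for phenyl at this position leaves the number within the usual scatter. This is a large change in what is attached: one heavy atom leaves, while 6 heavy atoms enter as a six-membered aromatic ring of carbon only. The earlier steps shown here changed only which bromo or fluoro groups the aromatic ring carried, so they could not show that a second ring at this place is compatible with a number that stays close to that of compound 2. No measurement offered here gives a reason for this outcome, so the result records what happens without explaining it.

From the compounds shown here alone, a single pair of compounds cannot show how far this holds, and it remains open whether a different group at the same place, such as an amine, a carboxylic acid or a longer chain, would also leave the number within the scatter or would move it clearly. Going by these compounds, whether a second ring would have the same outcome elsewhere on the aromatic ring also stays open.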